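This account rests on a few compounds, and the source may have more. Where it says the series, first, only, none or still open, it means among the compounds named here.

Compound 1 `Cc1cc(NC(=O)Nc2ccc(F)cc2)c2ccccc2n1` gives > 25000 nM
Compound 2 `Cc1cc(NC(=O)Nc2ccc(C(N)=O)cc2)c2ccccc2n1` gives > 25000 nM
Compound 3 `Cc1cc(NC(=O)Nc2ccc(O)cc2)c2ccccc2n1` gives > 25000 nM

In an ADME assay on HEK293 cells (Homo sapiens) for cytotoxicity, with a stated time of 72 h (a higher number here means that more compound is needed for the effect, a lower number that less compound is needed), compound 1 has only a limit and no number: it stands at the limit of > 25000 nM in this assay, at which 3 of the 3 values shown sit.

Compound 4 `Cc1cc(NC(=O)Nc2ccc(F)cc2F)c2ccccc2n1` carries one change from compound 1, fluoro in place of hydrogen on an aromatic carbon.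

The closest measured changes replace the fluoro group of compound 1, and neither gives a size: a step that the two limits leave unreadable from compound 1 to compound 2 and a step that the two limits leave unreadable from compound 1 to compound 3. With no readable size to go on, no step beyond the usual scatter is expected in this assay, and compound 4 will probably return only a limit too.

The expected step is a step that the limit leaves unreadable from compound 1 to compound 4 as an estimate only. For compound 4 the estimated value is 30000 nM with an expected range from 15000 nM to 60000 nM.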

Compound 4, half-maximal effective concentration: 10000 nM
Beside the measured number, compound 4's estimate is 3.0-fold (0.48 log units) above it; the whole stated range lies above it.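

In this assay, adding a fluoro group on an aromatic carbon, ortho to a large group and meta to a fluoro group, gives an at least 2.5-fold lower number from compound 1 to compound 4 (0.39 log units; beyond the scatter), so this position can respond to a small change. The true size may be larger, since compound 1 has only a limit. The steps among compound 1, compound 2 and compound 3 cannot be read, and only compound 4 has moved off the shared limit: the limit of > 25000 nM in this assay, at which 3 of the 4 values shown sit.

From the compounds shown here alone, whether a chloro, methoxy or amine group at this position would also lower the number remains open. So does whether the new fluoro group would act the same way if the hydroxy group of compound 3 replaced the original fluoro group.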